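Working notes: from compound 1 to compound 4

This account rests on a few compounds, and the source may have more. Where it says the series, first, only, none or still open, it means among the compounds named here.

Compound 1 `COc1ccc(C(=O)/C=C/c2ccc(Br)cc2)c2c1C=CC(C)(C)O2` sits at a limit in a functional assay on K562 cells (Homo sapiens) for antiproliferative activity, read by MTT assay, with a stated time of 24 h (on this read-out lower numbers stand for stronger inhibition and higher numbers for weaker inhibition), giving > 10000 nM, a limit of the assay rather than a number. Compound 2 `COc1ccc(C(=O)/C=C/c2ccc(-c3ccccc3)cc2)c2c1C=CC(C)(C)O2` likewise gives only a limit, > 10000 nM, in this assay. The step from compound 1 to compound 2, phenyl in place of bromo on an aromatic carbon, is a step that the two limits leave unreadable from compound 1 to compound 2 because of the limit of > 10000 nM in this assay, at which 2 of the 3 values shown sit. Among the compounds with values here, compound 3 `COc1ccc(C(=O)/C=C/c2ccc3ccccc3n2)c2c1C=CC(C)(C)O2` is the one member of the series with a number in this assay, 3020 nM.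

Compound 4 `COc1ccc(C(=O)/C=C/c2ccc(Cl)c(Cl)c2)c2c1C=CC(C)(C)O2` differs from compound 1 as follows: 3,4-dichlorophenyl in place of 4-bromophenyl on a double-bonded chain carbon bound to a double-bonded chain carbon. Within the data shown here, no measured step bears on this change; the only step cannot be read for size, and compound 1 itself stands at a limit, so the starting point is known only as a bound. The expectation is therefore that compound 4 also ends at or near the limit, with any gain staying small. Compound 4 is expected to give 8000 nM, within 2500 nM to 30000 nM. The expected step is an at least 1.2-fold lower number from compound 1 to compound 4 (0.09 log units; that floor lies within the scatter), measured against a limit.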

Compound 4, half-maximal inhibitory concentration: 9030 nM
Estimate against measurement, compound 4: 1.1-fold (0.05 log units) below, and the stated range covers the measured number.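

In this assay compound 4 gives 9030 nM, so 3,4-dichlorophenyl at this place gives a number rather than a limit, which neither compound 1 nor compound 2 gave. Compound 1 gives > 10000 nM, which is a limit of the assay and not a number. The change is read as an at least 1.1-fold lower number from compound 1 to compound 4 (0.04 log units; that floor lies within the scatter), so only a floor is known, and the one readable step in the halogen-bearing phenyl compounds cannot be told from the scatter, while the other step stays unreadable: the limit of > 10000 nM in this assay, at which 2 of the 4 values shown sit.

The compounds shown do not separate the effect of chlorine in place of bromine from that of a second halogen on the phenyl ring. Going by these compounds, it also remains open how this assay would read with an amine or a carboxylic acid on that phenyl ring.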